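The source may report more compounds than this note shows. Statements on the series, on what has been measured and on what is new or still open speak of the compounds shown alone.

Series notes. Compound 1 `CCC[S+]([O-])c1sc2nc(-c3cccs3)cc(C(=O)O)c2c1N` gives 71 nM in an assay for inhibition of 15-hydroxyprostaglandin dehydrogenase [NAD(+)] (Homo sapiens), read by fluorescence, with a stated time of 15 min, in the presence of a further agent that is not named here; a lower number here means a stronger inhibitor, a higher number a weaker inhibitor. Compound 2 `CCCC[S+]([O-])c1sc2nc(-c3nccs3)cc(-c3ccc(C(C)(C)O)cc3)c2c1N` gives 3.6 nM in this assay, and compound 3 `CCCC[S+]([O-])c1sc2nc(-c3nccs3)cc(-c3cccc(CO)c3)c2c1N` gives 4.3 nM. On these three numbers compound 3 stands second highest; its nearest neighbour lies within the scatter (a 1.2-fold higher number from compound 2 to compound 3 (0.08 log units; within the scatter)), while compound 1 lies furthest away, with a number beyond the scatter from that of compound 3.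

Compound 4 `CCCC[S+]([O-])c1sc2nc(-c3nccs3)cc(-c3nccs3)c2c1N` has not been measured in this assay. It differs from compound 3 in one place: 1,3-thiazol-2-yl in place of 3-(hydroxymethyl)phenyl on an aromatic carbon. Among the measured compounds shown here, only one measured step touches this position, a 1.2-fold higher number from compound 2 to compound 3 (0.08 log units; within the scatter), and it shows that exchanging one six-membered aromatic ring of carbon only for another there left the number within the scatter. For the measured compounds named here, no measured step exchanges such a ring for a five-membered aromatic ring with 2 hetero atoms, and the loss of the 1 hydrogen-bond donor is untested. The expectation for compound 4 is therefore a step of a 1.9-fold higher number from compound 3 to compound 4 (0.27 log units; within the scatter) of modest size, leaning to a higher number but possibly within the scatter. Compound 4 is estimated at 8 nM, with a range from 2.5 nM to 30 nM.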

Compound 4, half-maximal inhibitory concentration: 1.8 nM
Estimate against measurement, compound 4: 4.4-fold (0.65 log units) above; the whole stated range lies above it.
By their numbers in this assay, from the lowest: compounds 4, 2 and 3 (each within the scatter of the next, the first and the last beyond it); then compound 1.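

In this assay the position opposite the ring nitrogen tolerates a five-membered aromatic ring with 2 hetero atoms in place of a six-membered aromatic ring of carbon only, with a 2.4-fold lower number from compound 3 to compound 4 (0.38 log units; beyond the scatter) against 3-(hydroxymethyl)phenyl and a 2.0-fold lower number from compound 2 to compound 4 (0.30 log units; within the scatter) against 4-(1-hydroxy-1-methylethyl)phenyl. The low number of compound 4 also shows that a hydrogen-bond donor on this group is not needed, since 1,3-thiazol-2-yl has 0 hydrogen-bond donors and still gives a number no higher than those of the two phenyl compounds. Nothing on hand accounts for the change seen with this exchange.

From the compounds shown here alone, whether any aromatic ring is needed here remains open, and an amine or an open alkyl chain at this position would address that. Also open, going by these compounds, is how a hydroxymethyl group carried on the 1,3-thiazol-2-yl ring would compare with compound 4.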